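Aryl head group swap on the sulfonylacetic acid series

This account rests on a few compounds, and the source may have more. Where it says the series, first, only, none or still open, it means among the compounds named here.

Three compounds carry a benzyloxy-linked acid tail and differ in the aryl head. Compound 1 `COc1cc(C)c(-c2cccc(COc3ccc4c(c3)SCC4CC(=O)O)c2)c(C)c1` bears a bicyclic acid tail and in a functional assay on CHO cells for agonist activity at Free fatty acid receptor 1 (Homo sapiens), read by FLIPR and calcium flux (a lower number here means that less compound is needed, a higher number that more compound is needed for the effect), compound 1 gives 123 nM. Compound 2 `Cc1cc(OCCCS(C)(=O)=O)cc(C)c1-c1cccc(COc2ccc(S(=O)(=O)CC(=O)O)cc2)c1` has the sulfonylacetic acid tail together with a methylsulfonylpropoxy-substituted head, and in this assay compound 2 gives 170 nM. Compound 3 `Cc1ccccc1-c1cccc(COc2ccc(S(=O)(=O)CC(=O)O)cc2)c1` keeps the same tail with a plain 2-methylphenyl head; in this assay compound 3 gives 46.8 nM, the lowest number of the three, and both of its gaps, to compound 1 and to compound 2, lie beyond the usual scatter. Among the compounds with values here, no pair of these three differs in a single place, so no isolated step can be read from them.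

Compound 4 `CCOc1ccc(-c2cccc(COc3ccc(S(=O)(=O)CC(=O)O)cc3)c2)c(Cl)c1` is the next member to be tested. It differs from compound 3 in one place: 2-chloro-4-ethoxyphenyl in place of 2-methylphenyl on an aromatic carbon

With nothing directly comparable among the measured compounds, the step from compound 3 to compound 4 is expected to be small in the direction of a higher number, or none beyond the scatter: a 1.4-fold higher number from compound 3 to compound 4 (0.14 log units; within the scatter). For compound 4 in this assay the estimate is 65 nM, with a range from 20 nM to 200 nM.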

Compound 4, half-maximal effective concentration in the Free fatty acid receptor 1 assay: 51.3 nM
Beside the measured number, compound 4's estimate is 1.3-fold (0.10 log units) above it; the measured number falls inside the stated range.
By their numbers in the Free fatty acid receptor 1 assay, from the lowest: compounds 3 and 4 (each within the scatter of the next); then compounds 1 and 2 (each within the scatter of the next).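

On an aromatic carbon of the six-membered ring, meta to a large group, 2-chloro-4-ethoxyphenyl replaces 2-methylphenyl with no change beyond the scatter in the Free fatty acid receptor 1 assay: a 1.1-fold higher number from compound 3 to compound 4 (0.04 log units; within the scatter). Within the data shown here, this is the first single-place step, and it shows that the position takes the larger head, with 10 heavy atoms in place of 7 and one hydrogen-bond acceptor in place of none, while the receptor read-out stays level. In a physicochemical assay for lipophilicity, using the shake flask method, in phosphate buffer, measured as octanol-water partition, with a stated time of 24 h, at pH 7.4, tested at 100 uM (on this read-out lower numbers stand for lower lipophilicity and higher numbers for higher lipophilicity), compound 3 gives 2.35 and compound 4 gives 3.12 as the distribution coefficient. The same change does move lipophilicity, and by more than the scatter, as the physicochemical assay shows: the measured distribution coefficient of compound 3, 2.35, and of compound 4, 3.12, a number 0.77 log units higher (beyond the scatter)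

The chlorine and the ethoxy enter together, so the part each plays in either read-out cannot be separated from this one step. Also open, going by these compounds, is how both read-outs would respond to a head carrying an amine or a carboxylic acid in place of the ethoxy, and whether a head of that kind would keep the number in the Free fatty acid receptor 1 assay level while bringing the distribution coefficient back down.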